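The compounds below may be only part of what the source reports. "The series", "measured", "known", "first", "only" and "open" are said of these compounds alone.

In a functional assay on HL-60 cells (Homo sapiens) for antiproliferative activity, read by MTT assay, with a stated time of 48 h (on this read-out lower numbers stand for stronger inhibition and higher numbers for weaker inhibition), compound 1 (`COC/C1=C/C[C@](C)(CCC=C(C)C)/C=C/[C@@H](OC(=O)C=C(C)C)[C@](C)(O)/C=C/C1=O`) gives 3070 nM and compound 2 (`CC(C)=CCC[C@]1(C)/C=C/[C@@H](OC(=O)C=C(C)C)[C@](C)(O)/C=C/C(=O)/C(CN2CCCC2)=C\C1`) gives 160 nM as the lower of the two numbers. Compound 3 (`CSC(=S)OC/C1=C/C[C@](C)(CCC=C(C)C)/C=C/[C@@H](OC(=O)C=C(C)C)[C@](C)(O)/C=C/C1=O`) has not yet been measured. It differs from compound 2 in one place, on a saturated chain carbon bound to a double-bonded ring carbon: a group of 5 heavy atoms (2 carbon, 1 oxygen, 2 sulfur; no ring) in place of a group of 5 heavy atoms (4 carbon, 1 nitrogen; one five-membered non-aromatic ring with 1 hetero atom), on a saturated chain carbon bound to a double-bonded ring carbon is the whole change. Going by the values given here, one measured step bears on it, a 19-fold lower number from compound 1 to compound 2 (1.28 log units; beyond the scatter) in which pyrrolidin-1-yl replaced methoxy at that same place. Compound 3 loses pyrrolidin-1-yl, and the group that enters holds no nitrogen, like the methoxy of compound 1 at 3070 nM in the same read-out. A large move toward a higher number is therefore expected in this assay though perhaps not all the way back. For compound 3 the expected step is a 9.4-fold higher number from compound 2 to compound 3 (0.97 log units; beyond the scatter) as an estimate resting on a single measured step. For compound 3 the estimated value is 1500 nM with an expected range from 400 nM to 5000 nM as its ends.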

Compound 3, half-maximal inhibitory concentration: 180 nM
The estimate for compound 3 lay 8.3-fold (0.92 log units) above the measured number; measured number below the stated range.
By their numbers in this assay, from the lowest: compounds 2 and 3 (each within the scatter of the next); then compound 1.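

In this assay, the exchange of pyrrolidin-1-yl for a group of 5 heavy atoms (2 carbon, 1 oxygen, 2 sulfur; no ring) gives a 1.1-fold higher number from compound 2 to compound 3 (0.05 log units; within the scatter), so at this place, on a saturated chain carbon bound to a double-bonded ring carbon, the low number of compound 2 does not depend on a nitrogen among the compounds shown. Methoxy alone stands apart: the data show a 17-fold lower number from compound 1 to compound 3 (1.23 log units; beyond the scatter), a large step for a change made on the oxygen on a saturated carbon. No available evidence accounts for these results.

From the compounds shown here alone, whether a hydroxyl group, a morpholin-4-yl group or a dimethylamino group at this place would give a number like that of compound 2 or that of compound 1 remains open.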